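Swapping the para substituent on the pendant phenyl ring

This account rests on a few compounds, and the source may have more. Where it says the series, first, only, none or still open, it means among the compounds named here.

Measured so far:
Compound 1, `CCCS(=O)(=O)Nc1ccc(F)c(C(=O)c2n[nH]c3ncc(-c4ccc(F)cc4)cc23)c1F`, gives 2.1%.
Compound 2, `CCCS(=O)(=O)Nc1ccc(F)c(C(=O)c2n[nH]c3ncc(-c4ccc(OC)cc4)cc23)c1F`, gives 4.2%.
Compound 3, `CCCS(=O)(=O)Nc1ccc(F)c(C(=O)c2n[nH]c3ncc(-c4ccc(C(C)C)cc4)cc23)c1F`, gives 17%.

All three compounds share one core and differ only in the group on the outer aromatic ring. In an assay for binding affinity to dual specificity mitogen-activated protein kinase kinase 4 (Homo sapiens), read by KINOMEscan, tested at 100 nM (a lower number here means a stronger effect, a higher number a weaker effect of the compound at the concentration tested), compound 3 stands highest of the three numbers; its nearest neighbour is compound 2, with a number 12.8 percentage points higher from compound 2 to compound 3 (beyond the scatter), and the furthest is compound 1, with a number 14.9 percentage points higher from compound 1 to compound 3 (beyond the scatter). Both of those steps went beyond the scatter, whereas a number 2.1 percentage points higher from compound 1 to compound 2 (within the scatter) stayed within it.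

Compound 4, `CCCS(=O)(=O)Nc1ccc(F)c(C(=O)c2n[nH]c3ncc(-c4ccc(C(N)=O)cc4)cc23)c1F`, has not yet been measured. It differs from compound 3 in one place: carbamoyl in place of isopropyl on an aromatic carbon. The two steps that bear on this change are the ones that introduced isopropyl from fluoro and from methoxy, both modest and both upward. Since both other groups tried at this place gave lower numbers than compound 3, compound 4 is expected to move back down, with a step of about a number 11 percentage points lower from compound 3 to compound 4 (beyond the scatter) in this assay. The estimate for compound 4 is therefore 6%, with a range from 1% to 25%.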

Compound 4, a percentage reported as activity, at one concentration (the size of the read-out at that concentration, not a potency): 0.15%
For compound 4 the middle estimate is 5.9 percentage points above the measured one, and the stated range ends above it.
By their numbers in this assay, from the lowest: compounds 4, 1 and 2 (each within the scatter of the next); then compound 3.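

In this assay, carbamoyl in place of isopropyl brings the number back down, with a number 16.9 percentage points lower from compound 3 to compound 4 (beyond the scatter), so the rise seen with isopropyl at this position is not shared by every group of that size: both groups have the same heavy-atom count. The carbamoyl group, which brings a hydrogen-bond donor and acceptor that isopropyl lacks, gives no separation from the two smaller changes, with a number 4.1 percentage points lower from compound 2 to compound 4 (within the scatter) and a number 2 percentage points lower from compound 1 to compound 4 (within the scatter), so compound 1, compound 2 and compound 4 cannot be ordered and, among these four, only compound 3 stands apart. Nothing available here explains why the isopropyl compound differs from the other three.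

As far as these compounds go, it remains open whether a carboxylic acid or an amine at this place would stay level with compound 4. From the compounds shown here alone, it is equally open whether a longer chain would raise the number as isopropyl does.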